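A few compounds are considered here, and "the series" means these few. Any claim that something is new, unique, unknown or untested is made for them only; others in the source may bear on it.

Measured in a functional assay on HeLa cells (Homo sapiens) for inhibition, read by CCK-8 assay, with a stated time of 48 h; on this read-out higher numbers stand for weaker inhibition and lower numbers for stronger inhibition:

Compound 1 `Cc1ccc(C2=NN(C3=NC(c4ccccc4)CS3)C(c3ccc4ccccc4c3)C2)cc1` gives 2460 nM.
Compound 2 `Cc1ccc(C2=NN(C3=NC(=O)CS3)C(c3ccc4ccccc4c3)C2)cc1` gives 1760 nM.
Compound 3 `Cc1ccc(C2=NN(C3=NC(c4ccccc4)CS3)C(c3cccc4ccccc34)C2)cc1` gives 4290 nM.

Compound 1 stands second highest of these three numbers. Its neighbours sit close: a 1.4-fold lower number from compound 1 to compound 2 (0.15 log units; within the scatter), and a 1.7-fold higher number from compound 1 to compound 3 (0.24 log units; within the scatter), both within the scatter. Compound 4 `Clc1ccc(C2=NN(C3=NC(c4ccccc4)CS3)C(c3ccc4ccccc4c3)C2)cc1` differs from compound 1 by chloro in place of methyl on an aromatic carbon. Neither measured step touches that aromatic carbon: one exchanges the group on the amine nitrogen, the other moves the attachment point of the naphthyl group. Among the compounds with values here, no measured step therefore bears directly on this change, and the two steps that exist were small. On that basis no step beyond the scatter is expected in this assay. Compound 4 is estimated at 2400 nM, with a range from 900 nM to 6500 nM, which would mean an expected step of a 1.0-fold lower number from compound 1 to compound 4 (0.01 log units; within the scatter).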

Compound 4, half-maximal inhibitory concentration: 7560 nM
Beside the measured number, compound 4's estimate is 3.2-fold (0.50 log units) below it; measured number above the stated range.
By their numbers in this assay, from the lowest: compounds 2, 1, 3 and 4 (each within the scatter of the next, the first and the last beyond it).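

In this assay, going from 4-methylphenyl to 4-chlorophenyl gives a 3.1-fold higher number from compound 1 to compound 4 (0.49 log units; beyond the scatter), the only step shown here that lies beyond the scatter. The exchange replaces a single heavy atom, yet this place on the aromatic ring responds more clearly than the changes on the amine nitrogen and at the naphthyl attachment did. Nothing available explains this rise. The compounds shown leave open how fluoro, methoxy or an amine would read at this place. From the compounds shown here alone, whether the same exchange gives a similar step with the other groups of compound 2 or compound 3 also remains open.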